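Compound 2 to compound 3: a 3,5-dimethoxyphenyl change

The source may hold more compounds than are shown below. What is called first, only, known or untested is meant among the compounds shown, and "the series" means these compounds.

In a functional assay on G55T2 cells (Homo sapiens) for antiproliferative activity, read by WST assay, with a stated time of 72 h (a higher number here means a weaker inhibitor, a lower number a stronger inhibitor), compound 1 (`Cc1cc(C)cc(C(=O)N(CCC(=O)NCc2ccccc2)Cc2ccc(C(=O)NO)cc2)c1`) gives 4250 nM and compound 2 (`O=C(CCN(Cc1ccc(C(=O)NO)cc1)C(=O)c1ccccc1)NCc1ccccc1`) gives 5940 nM, so the two stand within the scatter of each other. Compound 3 (`COc1cc(OC)cc(C(=O)N(CCC(=O)NCc2ccccc2)Cc2ccc(C(=O)NO)cc2)c1`) has 3,5-dimethoxyphenyl in place of phenyl on a carbonyl carbon. Within the data shown here, the only measured change at this place is a 1.4-fold higher number from compound 1 to compound 2 (0.15 log units; within the scatter). Among the measured compounds shown here, no measured compound carries the new group, so the evidence is thin. No step beyond the scatter is expected in this assay, and the expected step is a 1.2-fold lower number from compound 2 to compound 3 (0.09 log units; within the scatter). The estimate for compound 3 is 4800 nM, with an expected range of 2200 nM to 10000 nM.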

Compound 3, half-maximal inhibitory concentration: 14700 nM
The estimate for compound 3 lay 3.1-fold (0.49 log units) below the measured number, and the stated range ends below it.
By their numbers in this assay, from the lowest: compounds 1 and 2 (each within the scatter of the next); then compound 3.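

In this assay, the place on the carbonyl carbon showed no step beyond the scatter between phenyl and 3,5-dimethylphenyl, but 3,5-dimethoxyphenyl does (a 2.5-fold higher number from compound 2 to compound 3 (0.39 log units; beyond the scatter); a 3.5-fold higher number from compound 1 to compound 3 (0.54 log units; beyond the scatter)). Among these three compounds, the higher number goes with the methoxy groups of 3,5-dimethoxyphenyl, since compound 1, which carries 3,5-dimethylphenyl instead, does not show it. Nothing measured here accounts for this step. Still open, from the compounds shown here alone, is whether a single methoxy group would give a step of the same size. Also open, going by these compounds, is how an amine or a carboxylic acid on the ring would compare.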